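The source may hold more compounds than are shown below. What is called first, only, known or untested is meant among the compounds shown, and "the series" means these compounds.

Measured in an ADME assay on Vero cells (Chlorocebus sabaeus) for cytotoxicity, read by MTT assay, with a stated time of 72 h; a higher number here means that more compound is tolerated, a lower number that less compound is tolerated:
- compound 1 `COc1ccc([C@H](O)COC(=O)/C=C/c2ccccc2)cc1OC`: 24300 nM
- compound 2 `COc1ccc([C@@H](O)COC(=O)/C=C/c2ccccc2)cc1OC`: 5870 nM
- compound 3 `COc1cccc([C@H](O)COC(=O)/C=C/c2ccccc2)c1`: 61900 nM

Compound 3 has the highest number of the three in this assay, at 61900 nM. The nearest is compound 1 at 24300 nM, which sits below compound 3 by more than the scatter: a 2.5-fold higher number from compound 1 to compound 3 (0.41 log units; beyond the scatter). That step is hydrogen in place of methoxy on an aromatic carbon and says nothing about configuration.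

Compound 4 `COc1cccc([C@@H](O)COC(=O)/C=C/c2ccccc2)c1` is reached from compound 3 by the two compounds have the same atoms and bonds and differ only in configuration as drawn: 1 of 2 stereo elements differ; a stereocentre at a saturated chain carbon is drawn S in compound 3 and R in compound 4. A stereocentre at a saturated chain carbon is drawn S in compound 3 and R in compound 4.

Among the measured compounds shown here, the one measured step of this kind is a 4.1-fold lower number from compound 1 to compound 2 (0.62 log units; beyond the scatter), a change from S to R that lies beyond the scatter. It can be put down to configuration alone, given (the fact that compounds 1 and 2 differ only in the configuration as drawn). This is a single pair, measured with the additional methoxy present, so its size may not carry over exactly. A step of similar size in the same direction is still the best expectation for this assay, meaning less compound tolerated.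

The expected change is a 3.9-fold lower number from compound 3 to compound 4 (0.59 log units; beyond the scatter).

For compound 4 the estimated value is 16000 nM, with an expected range of 6000 nM to 50000 nM.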

Compound 4, half-maximal cytotoxic concentration: 22300 nM
Beside the measured number, compound 4's estimate is 1.4-fold (0.14 log units) below it; low and high end bracket the measured number.
By their numbers in this assay, from the lowest: compound 2; then compounds 4 and 1 (each within the scatter of the next); then compound 3.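

In this assay, the change from S to R at the saturated chain carbon now appears on a second core, a 2.8-fold lower number from compound 3 to compound 4 (0.44 log units; beyond the scatter), in the same direction as a 4.1-fold lower number from compound 1 to compound 2 (0.62 log units; beyond the scatter), so the drop in the number is not confined to the core with the additional methoxy, and this second step can be put down to configuration alone: the fact that compounds 3 and 4 differ only in the configuration as drawn. Hydrogen in place of methoxy on an aromatic carbon can now also be read with the stereocentre drawn R, a 3.8-fold higher number from compound 2 to compound 4 (0.58 log units; beyond the scatter), and it raises the number there as it does with the stereocentre drawn S, so the two readings can be set side by side: the same change on two cores in this assay, a 2.5-fold higher number (0.41 log units; beyond the scatter) from compound 1 to compound 3 and a 3.8-fold higher number (0.58 log units; beyond the scatter) from compound 2 to compound 4, 1.5-fold (0.17 log units) apart, within the scatter of two such steps. Across these four compounds, neither change reverses direction when the other is made.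

The compounds shown leave open whether the S to R step keeps its direction when an amide replaces the ester, or when a hydroxyl or an amine replaces the remaining methoxy. They also give no measured property that would explain either change.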